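A Hydroxymethyl Chain on the Shared Core

The compounds below may be only part of what the source reports. "The series", "measured", "known", "first", "only" and "open" are said of these compounds alone.

For the measured compounds named here, in a functional assay on HL-60 cells (Homo sapiens) for cytotoxicity, read by WST assay, with a stated time of 48 h (on this read-out lower numbers stand for stronger inhibition and higher numbers for weaker inhibition), compound 1 (`COC[C@H](C)[C@@H](C)C(c1ccc(O)c(OC)c1)c1ccc(O)c(OC)c1`) gives 68000 nM, while compound 2 (`CC[C@H](C(C)C)C(c1ccc(O)c(OC)c1)c1ccc(O)c(OC)c1`) gives 16000 nM, the lower of the two numbers so far. Compound 3 (`COc1cc(C(c2ccc(O)c(OC)c2)[C@H](C)[C@@H](C)CO)ccc1O`) has not yet been measured. In it, 2-(hydroxymethyl)-1-methylpropyl stands in place of the 1-isopropylpropyl of compound 2, on a saturated chain carbon bound to two aromatic carbons (2-(hydroxymethyl)-1-methylpropyl in place of 1-isopropylpropyl on a saturated chain carbon bound to two aromatic carbons). Going by the values given here, only one measured step bears on this change: a 4.3-fold lower number from compound 1 to compound 2 (0.63 log units; beyond the scatter), a modest step beyond the scatter, which leads from 2-(methoxymethyl)-1-methylpropyl to 1-isopropylpropyl. Compound 3 also carries an oxygen on its chain, so that single step suggests a move back toward a higher number, of similar modest size. The expected step is a 3.4-fold higher number from compound 2 to compound 3 (0.54 log units; beyond the scatter). For compound 3 the estimated value is 55000 nM, with an expected range of 22000 nM to 140000 nM.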

Compound 3, half-maximal inhibitory concentration: > 100000 nM
Compound 3: a limit, no number; the forecaster's own chance of this, stated with the estimate: 15%; middle value at least 1.8-fold (0.25 log units) away from the limit.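

In this assay compound 3 gives > 100000 nM, which is a limit of the assay and not a number: the limit of > 100000 nM in this assay, at which 1 of the 3 values shown sits. The change to 2-(hydroxymethyl)-1-methylpropyl on a saturated chain carbon bound to two aromatic carbons gives an at least 6.2-fold higher number from compound 2 to compound 3 (0.79 log units; beyond the scatter), so a second chain carrying oxygen now stands on the high side of the all-carbon 1-isopropylpropyl, where only the 2-(methoxymethyl)-1-methylpropyl chain stood before. Hydrogen in place of methyl on that chain oxygen gives an at least 1.4-fold higher number from compound 1 to compound 3 (0.16 log units; that floor lies within the scatter), so the two oxygen-bearing chains cannot be put in order.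

On these data alone, the true size of both steps stays open, since only a limit is available for compound 3. Also open, as far as these compounds go, is how a chain ending in an amine or a carboxylic acid, or a longer all-carbon chain, would read at this place.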